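The source may report more compounds than this note shows. Statements on the series, on what has been measured and on what is new or still open speak of the compounds shown alone.

Measured compounds:
- compound 1, `COc1cc(C(=O)NC2CCN(Cc3ccc4ccccc4c3)CC2)cc(OC)c1OC`: 286 nM
- compound 2, `COc1cc(OC)cc(C(=O)N[C@@H]2CCN(C/C=C/c3ccccc3)C2)c1`: 17 nM
- compound 3, `COc1cc(OC)cc(C(=O)N[C@@H]2CCN(C(C)/C=C/c3ccccc3)C2)c1`: 23 nM

In an assay on isolated protein for binding affinity to melanin-concentrating hormone receptor 1 (Homo sapiens) (on this read-out higher numbers stand for weaker inhibition and lower numbers for stronger inhibition), compound 2 gives 17 nM, the lowest of the three numbers. Compound 3 sits nearest to it, and the step of a 1.4-fold higher number from compound 2 to compound 3 (0.13 log units; within the scatter) lies within the scatter. For the measured compounds named here, compound 1, with its different ring and core substitution, gives 286 nM, a much higher number than compound 2, but no single-point step links the two.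

The unmeasured compound 4, `COc1cc(OC)cc(C(=O)N[C@@H]2CCN(Cc3ccccc3)C2)c1`, differs from compound 2 in one place: phenyl in place of 2-phenylethenyl on a saturated chain carbon bound to an amine nitrogen in a ring. Going by the values given here, only one measured step touches this region, the step of a 1.4-fold higher number from compound 2 to compound 3 (0.13 log units; within the scatter), which placed a methyl on the same saturated chain carbon and left the number essentially unchanged. That step added to the chain; the change to compound 4 shortens it and removes the double bond, so the measured step offers only indirect guidance. Among the compounds with values here, with no direct precedent, a modest rise in the number is expected rather than a large one.

Compound 4 is therefore estimated at 60 nM in this assay, with a range from 15 nM to 250 nM, which corresponds to an expected step of a 3.5-fold higher number from compound 2 to compound 4 (0.55 log units; beyond the scatter).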

Compound 4, inhibition constant: 8070 nM
Estimate against measurement, compound 4: 130-fold (2.13 log units) below, outside the stated range (above it).
By their numbers in this assay, from the lowest: compounds 2 and 3 (each within the scatter of the next); then compound 1; then compound 4.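

In this assay, the exchange of 3-phenylprop-2-en-1-yl for benzyl gives a 470-fold higher number from compound 2 to compound 4 (2.68 log units; beyond the scatter), and so this position proves highly sensitive to the group it carries. The earlier step, a 1.4-fold higher number from compound 2 to compound 3 (0.13 log units; within the scatter), had shown only that a methyl on the same saturated chain carbon leaves the number within the scatter, so the readings at this carbon depend strongly on which change is made: the added methyl kept the 2-phenylethenyl group in place, whereas this change removed it. Nothing in the available data explains the size of the new step.

The change shortens the chain and removes its double bond at once, so the compounds shown do not tell which of the two accounts for the rise; a 2-phenylethyl or a 3-phenylpropyl group at this place would separate them. They also leave open whether a methyl on the saturated chain carbon of the benzyl group would stay as silent as it did in the step to compound 3.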